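A methoxy group on a compound at the assay limit

The source may hold more compounds than are shown below. What is called first, only, known or untested is meant among the compounds shown, and "the series" means these compounds.

Compound 2 (`C=CC(=O)Nc1cccc(-n2cnc3cnc(Nc4ccc(N5CCN(S(C)(=O)=O)CC5)cc4)nc32)c1`) has been measured in a functional assay on Raji cells (Homo sapiens) for antiproliferative activity, read by CCK-8 assay, with a stated time of 48 h (on this read-out higher numbers stand for weaker inhibition and lower numbers for stronger inhibition), but has no exact place on the scale. Compound 2 gives > 40000 nM as its result, which is a limit of the assay and not a number. Compound 3 (`C=CC(=O)Nc1cccc(-n2cnc3cnc(Nc4ccc(N5CCN(C(C)=O)C(C)C5)cc4)nc32)c1`) gives 24200 nM as a true reading. Taken together, the picture is the limit of > 40000 nM in this assay, at which 2 of the 3 values shown sit, and the position of compound 2 stays open on the weak side.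

Compound 4 (`C=CC(=O)Nc1cccc(-n2cnc3cnc(Nc4ccc(N5CCN(S(C)(=O)=O)CC5)cc4OC)nc32)c1`) differs from compound 2 in one place: methoxy in place of hydrogen on an aromatic carbon. The methoxy sits ortho to a large group and meta to a 4-(methylsulfonyl)piperazin-1-yl group.

For the measured compounds named here, no measured step makes this change alone. Going by the values given here, the only step available is an at least 1.6-fold lower number from compound 2 to compound 3 (0.21 log units; that floor lies within the scatter) and it swaps a different group, so it bears only loosely on the methoxy. Compound 1 (`C=CC(=O)Nc1cccc(-n2cnc3cnc(Nc4ccc(N5CCN(CC)CC5)cc4OC)nc32)c1`) also carries a methoxy, and its > 40000 nM is again only a limit. In this assay no step beyond the scatter is therefore expected, and another limit is likely. The expected change is a number no higher from compound 2 to compound 4 (the limit leaves the size open) in size. The estimate for compound 4 is an expected 40000 nM with a range from 18000 nM to 80000 nM around it.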

Compound 4, half-maximal inhibitory concentration: 21900 nM
Estimate against measurement, compound 4: 1.8-fold (0.26 log units) above, within the range that was stated.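

Methoxy in place of hydrogen, on the aromatic carbon ortho to a large group and meta to a 4-(methylsulfonyl)piperazin-1-yl group, gives an at least 1.8-fold lower number from compound 2 to compound 4 (0.26 log units; that floor lies within the scatter) in this assay. For the compounds shown here, this is the first time the change can be followed at this position, and it turns a limit into a true reading, although the floor of the step is too small to count as a real gain. The methoxy does not bring a true reading on its own, since methylsulfonyl in place of ethyl on an amine nitrogen in a ring, with the methoxy kept, gives an at least 1.8-fold lower number from compound 1 to compound 4 (0.26 log units; that floor lies within the scatter), and the true size of both steps stays unknown because one end of each is only a limit: the limit of > 40000 nM in this assay, at which 2 of the 4 values shown sit.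

From the compounds shown here alone, whether a hydroxyl group, a fluorine atom or a longer chain such as ethoxy on this same aromatic carbon would also give a true reading remains open. Going by these compounds, it is also open whether a methoxy here would shift the reading of compound 3, which carries the 4-acetyl-3-methylpiperazin-1-yl group in place of the 4-(methylsulfonyl)piperazin-1-yl group.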